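The source may hold more compounds than are shown below. What is called first, only, known or untested is meant among the compounds shown, and "the series" means these compounds.

Measured compounds in a functional assay on IGROV-1 cells (Homo sapiens) for inhibition, read by sulforhodamine B assay, with a stated time of 48 h; a lower number here means a stronger inhibitor of growth, a higher number a weaker inhibitor of growth:
compound 1 `COc1ccc(-c2ccc(-c3ccc(C(=N)N)o3)o2)cc1` gives 1730 nM
compound 2 `COc1cc(OC)cc(-c2ccc(-c3ccc(C(=N)N)o3)o2)c1` gives 2970 nM
compound 3 `N=C(N)c1ccc(-c2ccc(-c3ccc4ccccc4c3)s2)s1` gives 2160 nM

Compound 1 has the lowest of the three numbers, but neither gap sets it apart: compound 3 lies within the scatter of compound 1, and so does compound 2. On these three numbers the series is flat, and none of the three can be called stronger or weaker than another.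

Compound 4 `N=C(N)c1ccc(-c2ccc(-c3ccc(F)cc3)o2)o1` is not yet measured in this assay. Against compound 1 it shows a single change: fluoro in place of methoxy on an aromatic carbon. The change sits on an aromatic carbon of a six-membered aromatic ring of carbon only, para to a large group; the shared core is otherwise untouched.

Among the measured compounds shown here, no step between measured compounds is on hand to set the size of this change. For the measured compounds named here, the only guide is that three different end groups on the same core all land within the scatter of one another, which points to a small step. The expected step is therefore a 1.2-fold higher number from compound 1 to compound 4 (0.08 log units; within the scatter), most likely none beyond the scatter, with a weak lean toward a higher number. For compound 4 the estimate is 2100 nM, with a range from 900 nM to 5000 nM.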

Compound 4, concentration for 50% growth inhibition: 1580 nM
Compound 4: middle estimate off by 1.3-fold (0.12 log units), on the high side; the range from low to high includes it.
By their numbers in this assay, from the lowest: compounds 4, 1, 3 and 2 (each within the scatter of the next).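

In this assay, among the compounds shown here, fluoro in place of methoxy on an aromatic carbon, para to a large group, gives a 1.1-fold lower number from compound 1 to compound 4 (0.04 log units; within the scatter), the only step so far that isolates a change in one place on the shared core. Across this pair, going from methoxy, with 2 heavy atoms and 1 hydrogen-bond acceptor, to fluoro, with 1 heavy atom and 0 hydrogen-bond acceptors, leaves the number within the scatter, so neither difference registers as a change in growth inhibition at this position. Nothing on hand accounts for why the number holds across this change.

As far as these compounds go, whether this position stays as flat with groups of a different kind remains open: an amine, a carboxylic acid or a longer alkoxy chain on the same aromatic carbon would show whether the result extends beyond methoxy and fluoro. Also open, from the compounds shown here alone, is whether a single change elsewhere on the shared core, with fluoro kept in place, would move the number in this assay beyond the scatter.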